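A few compounds are considered here, and "the series" means these few. Any claim that something is new, unique, unknown or untested is made for them only; others in the source may bear on it.

Series notes. Among the compounds with values here, compound 1 `O=C(Nc1cc(C(F)(F)F)cc(C(F)(F)F)c1)C1CCc2ccccc2N1C(=O)c1ccc(Cl)cc1` is the only member with a number in a functional assay on HCT-15 cells (Homo sapiens) for cytotoxicity, read by sulforhodamine B assay, with a stated time of 72 h; on this read-out lower numbers stand for stronger inhibition of growth and higher numbers for weaker inhibition of growth: compound 1 gives 2220 nM. Compound 2 `CCCC(=O)N1c2ccccc2CCC1C(=O)Nc1ccccc1C(F)(F)F` carries a butanoyl group on the ring nitrogen and a single trifluoromethyl on the anilide. In this assay compound 2 is reported only as a limit, > 70000 nM. Within the data shown here, that leaves one of the two values sitting at the limit of > 70000 nM in this assay, at which 1 of the 2 values shown sits, so no measured step between compounds is available, and the pair of compound 1 and compound 2 differ in two places at once.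

Compound 3 `CCCCCCCCC(=O)N1c2ccccc2CCC1C(=O)Nc1cc(C(F)(F)F)cc(C(F)(F)F)c1` keeps the anilide of compound 1 and alters the acyl group on the ring nitrogen: octyl in place of 4-chlorophenyl on a carbonyl carbon. Among the measured compounds shown here, with no measured step to lean on, the expectation for compound 3 in this assay is a loss of potency, with a step of a 3.2-fold higher number from compound 1 to compound 3 (0.50 log units; beyond the scatter) that reaches beyond the scatter. Compound 3 is expected to give about 7000 nM, within a range from 1500 nM to 40000 nM.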

Compound 3, concentration for 50% growth inhibition: 4970 nM
Compound 3: middle estimate off by 1.4-fold (0.15 log units), on the high side, and the stated range covers the measured number.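

With the anilide of compound 1 held constant, the acyl group on the ring nitrogen now has its first measured step in this assay: replacing 4-chlorophenyl with octyl on a carbonyl carbon gives a 2.2-fold higher number from compound 1 to compound 3 (0.35 log units; beyond the scatter). The step is modest, and compound 3 still gives a number rather than a limit, so an aromatic ring at this place is not required for measurable growth inhibition. No measured property in the series bears on the size of this step. Still open, as far as these compounds go, is whether the step follows from losing the ring, the chlorine or both, which a plain phenyl on the same carbonyl would begin to separate. Also open, from the compounds shown here alone, is how a shorter chain, or an octyl chain ending in an amine or a carboxylic acid, would read.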